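This account rests on a few compounds, and the source may have more. Where it says the series, first, only, none or still open, it means among the compounds named here.

Three compounds share one core and differ only in the group attached to a carbonyl carbon. Compound 1 `CC(C)(C)OC(=O)N1CCC[C@H]1C(=O)N1CCC(NS(=O)(=O)c2cc(S(=O)(=O)c3ccccc3)ccc2C(F)(F)F)CC1` gives 60 nM in a functional assay on U2OS cells for antagonist activity at proto-oncogene Wnt-3 (Homo sapiens), read by a luciferase reporter, with a stated time of 18 h; on this read-out lower numbers stand for an effect already at smaller amounts and higher numbers for an effect only at larger amounts of compound. Compound 2 `O=C1CC[C@@H](C(=O)N2CCC(NS(=O)(=O)c3cc(S(=O)(=O)c4ccccc4)ccc3C(F)(F)F)CC2)N1` gives 240 nM in this assay, and compound 3 `CN(C)C(=O)N1CCC[C@H]1C(=O)N1CCC(NS(=O)(=O)c2cc(S(=O)(=O)c3ccccc3)ccc2C(F)(F)F)CC1` gives 160 nM in this assay. Compound 3 thus stands second highest of the three numbers; it lies close to compound 2, within the usual scatter, while compound 1 lies further off, with a 2.7-fold higher number from compound 1 to compound 3 (0.43 log units; beyond the scatter).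

Compound 4 `CN1CCC[C@H]1C(=O)N1CCC(NS(=O)(=O)c2cc(S(=O)(=O)c3ccccc3)ccc2C(F)(F)F)CC1` carries a smaller group again: methyl in place of dimethylcarbamoyl on an amine nitrogen in a ring. Going by the values given here, no measured step shows exactly this change. The steps that come nearest are a 2.7-fold higher number from compound 1 to compound 3 (0.43 log units; beyond the scatter) and a 4.0-fold higher number from compound 1 to compound 2 (0.60 log units; beyond the scatter), both of which replaced the tert-butoxy group of compound 1 with something smaller and both of which raised the number. Trimming further to a single methyl is therefore expected to give a modest rise of roughly a 2.5-fold higher number from compound 3 to compound 4 (0.40 log units; beyond the scatter), although a step of this kind could just as well stay within the scatter. For compound 4 the expected value in this assay is 400 nM, within a range from 120 nM to 1500 nM.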

Compound 4, half-maximal effective concentration: 230 nM
Estimate against measurement, compound 4: 1.7-fold (0.24 log units) above; measured number inside the range.
By their numbers in this assay, from the lowest: compound 1; then compounds 3, 4 and 2 (each within the scatter of the next).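

On the amine nitrogen in a ring, swapping dimethylcarbamoyl (5 heavy atoms) for methyl (1 heavy atom) gives, in this assay, a 1.4-fold higher number from compound 3 to compound 4 (0.16 log units; within the scatter), and the change from the 5-oxopyrrolidin-2-yl group of compound 2 to the 1-methylpyrrolidin-2-yl group gives a 1.0-fold lower number from compound 2 to compound 4 (0.02 log units; within the scatter), so this large drop in group size leaves the number inside the usual scatter. The gap from the tert-butoxycarbonyl group remains, with a 3.8-fold higher number from compound 1 to compound 4 (0.58 log units; beyond the scatter), so among these four compounds only compound 1 stands apart, and the rise seen on leaving its group does not grow further as the group shrinks to methyl. Nothing measured here accounts for the separate place of compound 1.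

On these data alone, what remains open is whether the number of compound 1 depends on the bulky tert-butyl part or on the carbonyl that joins it to the ring nitrogen, which a tert-butyl group set directly on that nitrogen or an acetyl group there could help to separate. The compounds shown also leave open how the free amine, with only a hydrogen on that nitrogen, or a longer chain such as butyl would compare.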